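Three Limits and a Dichlorophenyl Swap

This account rests on a few compounds, and the source may have more. Where it says the series, first, only, none or still open, it means among the compounds named here.

In a functional assay on MCF7 cells (Homo sapiens) for antiproliferative activity, read by MTT assay, with a stated time of 72 h (on this read-out higher numbers stand for weaker inhibition and lower numbers for stronger inhibition), three compounds sharing one core have so far returned no number. Compound 1 (`COc1cc(-c2ncnn2-c2cccc(F)c2)cc(OC)c1OC`) gives only a limit, > 10000 nM. Compound 2 (`COc1cc(-c2ncnn2-c2ccc([N+](=O)[O-])cc2)cc(OC)c1OC`) also gives only a limit, > 10000 nM. Compound 3 (`COc1cc(-c2ncnn2-c2ccc(N)cc2)cc(OC)c1OC`) stands at a limit too, > 10000 nM, and its place in the series is summed up by the limit of > 10000 nM in this assay, at which 3 of the 3 values shown sit.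

Compound 4 (`COc1cc(-c2ncnn2-c2ccc(Cl)c(Cl)c2)cc(OC)c1OC`) differs from compound 3 by one change: 3,4-dichlorophenyl in place of 4-aminophenyl on an aromatic nitrogen. In words, 3,4-dichlorophenyl sits in place of 4-aminophenyl on an aromatic nitrogen.

Among the compounds with values here, two measured steps bear on this change, a step that the two limits leave unreadable from compound 1 to compound 3 and a step that the two limits leave unreadable from compound 2 to compound 3, and neither has a readable size. Within the data shown here, the 3-fluorophenyl of compound 1 is the only other halogen-bearing group, and compound 1 remains at the limit of > 10000 nM. No clear shift is therefore expected, and the data support no direction. The expected change is a step that the limit leaves unreadable from compound 3 to compound 4. For compound 4 the estimated value is 12000 nM, with an expected range of 3000 nM to 40000 nM.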

Compound 4, half-maximal inhibitory concentration: > 10000 nM
Compound 4: a limit, no number; the forecaster's own chance of this, stated with the estimate: 75%; the middle value lies beyond the limit too.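

Compound 4 also returns only a limit in this assay, so its steps from compound 1 and from compound 3 cannot be read. The compounds shown leave open which group on the aromatic nitrogen, if any, gives a measurable potency: the limit of > 10000 nM in this assay, at which 4 of the 4 values shown sit.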